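The source may report more compounds than this note shows. Statements on the series, on what has been measured and on what is new or still open speak of the compounds shown alone.

Measured so far:
compound 1, `O=C(Nc1ccc(Oc2cc(C(F)(F)F)cc(C(F)(F)F)c2)cc1)c1cc(Cl)ccc1F`, 1110 nM
compound 2, `O=C(Nc1ccc(Oc2cc(C(F)(F)F)cc(C(F)(F)F)c2)cc1)c1c(F)cccc1OC(F)(F)F`, > 50000 nM

Both compounds share one core and differ only in the ring attached to the carbonyl carbon. In an assay on HEK293 cells for inhibition of Toll-like receptor 8 (Homo sapiens), with a stated time of 16 h (a higher number here means a weaker inhibitor, a lower number a stronger inhibitor), compound 1 gives 1110 nM. Compound 2 gives only a limit in this assay, > 50000 nM, so its exact potency is not known. Compound 2 therefore sits at the limit of > 50000 nM in this assay, at which 1 of the 2 values shown sits. Going by the values given here, the single measured step, an at least 45-fold higher number from compound 1 to compound 2 (1.65 log units; beyond the scatter), shows how much potency is lost when the ring of compound 1 is replaced by the ring of compound 2. Compound 3, `O=C(Nc1ccc(Oc2cc(C(F)(F)F)cc(C(F)(F)F)c2)cc1)c1sccc1Cl`, has not yet been measured. It differs from compound 2 by a group of 6 heavy atoms (4 carbon, 1 sulfur, 1 chlorine; one five-membered aromatic ring with 1 hetero atom) in place of a group of 12 heavy atoms (7 carbon, 1 oxygen, 4 fluorine; one six-membered aromatic ring of carbon only), on a carbonyl carbon. The entering ring is closer in count to the ring of compound 1 than to that of compound 2, so the measured step is expected to run in reverse, and compound 3 is expected to regain potency, with an at least 33-fold lower number from compound 2 to compound 3 (1.52 log units; beyond the scatter). The estimate for compound 3 is 1500 nM, with a range from 300 nM to 10000 nM.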

Compound 3, half-maximal inhibitory concentration: 3200 nM
Beside the measured number, compound 3's estimate is 2.1-fold (0.33 log units) below it; measured number inside the range.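

Replacing the ring of compound 2 with 3-chlorothiophen-2-yl on the carbonyl carbon gives an at least 15-fold lower number from compound 2 to compound 3 (1.19 log units; beyond the scatter) in this assay, so a five-membered ring containing sulfur can stand here and still give a measurable number. The value of compound 2 is only a limit, which makes the size of that step a minimum: the limit of > 50000 nM in this assay, at which 1 of the 3 values shown sits. Placing 3-chlorothiophen-2-yl where compound 1 has 5-chloro-2-fluorophenyl gives a 2.9-fold higher number from compound 1 to compound 3 (0.46 log units; beyond the scatter), so the thiophene keeps inhibition at this position but does not match the phenyl ring of compound 1.

As far as these compounds go, both rings with an exact number carry chlorine, but they also differ from the ring of compound 2 in other ways, so the part played by chlorine stays open. Also open, from the compounds shown here alone, is how a ring bearing an amine or a carboxylic acid would fare on this carbonyl carbon.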